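The source may report more compounds than this note shows. Statements on the series, on what has been measured and on what is new or still open speak of the compounds shown alone.

Compound 1 `COc1cc(Cl)cc(-c2nn(-c3cccc(NC(=O)c4ccc(Cl)c(Cl)c4)c3)cc2-c2ccncc2)c1`: 72.8%
Compound 2 `COc1cc(Cl)cc(-c2nn(-c3cccc(NC(=O)Nc4cccc(C(F)(F)F)c4)c3)cc2-c2ccncc2)c1`: 4.64%
Compound 3 `COc1cc(Cl)cc(-c2nn(-c3cccc(NC(=O)c4cccc(C(F)(F)F)c4)c3)cc2-c2ccncc2)c1`: 51.7%

Three compounds on a shared core have been run in a functional assay on LOX IMVI cells (Homo sapiens) for inhibition, read by sulforhodamine B assay, with a stated time of 48 h, tested at 10 uM; on this read-out lower numbers stand for a stronger effect and higher numbers for a weaker effect at the one concentration tested. Compound 3 sits second highest of the three numbers; its nearest neighbour is compound 1, the step being a number 21.1 percentage points lower from compound 1 to compound 3 (beyond the scatter), and the furthest is compound 2, with a number 47.1 percentage points higher from compound 2 to compound 3 (beyond the scatter). The largest move in the set is a number 68.2 percentage points lower from compound 1 to compound 2 (beyond the scatter).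

Compound 4 `COc1cc(Cl)cc(-c2nn(-c3cccc(NC(=O)c4cc(C(F)(F)F)cc(C(F)(F)F)c4)c3)cc2-c2ccncc2)c1` has not yet been measured in this assay. It differs from compound 3 in one place: trifluoromethyl in place of hydrogen on an aromatic carbon. Among the measured compounds shown here, no measured step makes exactly this change. For the measured compounds named here, the only one touching the same ring is the swap of the whole aryl group on the carbonyl carbon, a number 21.1 percentage points lower from compound 1 to compound 3 (beyond the scatter), which was modest; there compound 1 carried a 3,4-dichlorophenyl and compound 3 a 3-(trifluoromethyl)phenyl. The steps of a number 68.2 percentage points lower from compound 1 to compound 2 (beyond the scatter) and a number 47.1 percentage points higher from compound 2 to compound 3 (beyond the scatter) concern the (3-(trifluoromethyl)phenyl)amino group and bear little on this change. A second trifluoromethyl is therefore expected to shift the read-out only modestly, with the direction uncertain. For compound 4 the expected step is a number 4.3 percentage points higher from compound 3 to compound 4 (within the scatter), an estimate drawn from that single loose precedent. The value expected for compound 4 is 56%, within a range from 30% to 82%.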

Compound 4, a percentage reported as activity, at one concentration (the size of the read-out at that concentration, not a potency): 76.1%
The estimate for compound 4 lay 20.1 percentage points below the measured number; measured number inside the range.
By their numbers in this assay, from the lowest: compound 2; then compound 3; then compounds 1 and 4 (each within the scatter of the next).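

In this assay, the aromatic carbon meta to a large group and meta to a trifluoromethyl group is not a neutral place for substitution: trifluoromethyl in place of hydrogen gives a number 24.4 percentage points higher from compound 3 to compound 4 (beyond the scatter), a weaker effect at the one concentration tested. Among the compounds shown here, this is the first step that adds a single group to this ring, rather than exchanging the whole aryl group on the carbonyl carbon, and it shows that such an addition alone moves the read-out beyond the scatter, in the opposite direction to the aryl exchange, a number 21.1 percentage points lower from compound 1 to compound 3 (beyond the scatter). Nothing measured on these compounds accounts for the shift.

The compounds shown have only hydrogen and trifluoromethyl at this position, so it remains open whether the weaker effect goes with trifluoromethyl in particular or with substitution there in general, a question that a fluorine, a methoxy or an amine at the same carbon would address. On these data alone, it also remains open whether a second trifluoromethyl on the aryl ring of compound 2 would change the read-out in the same direction.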